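Anilino-glutarimide phthalimides: methoxy to tert-butyl on the aryl ring

A few compounds are considered here, and "the series" means these few. Any claim that something is new, unique, unknown or untested is made for them only; others in the source may bear on it.

Measured compounds:
compound 1 `COc1ccc(Nc2ccc3c(c2)C(=O)N(C2CCC(=O)NC2=O)C3=O)cc1`: 29%
compound 2 `O=C1CCC(N2C(=O)c3cccc(Nc4ccccn4)c3C2=O)C(=O)N1`: 1%
compound 3 `Cc1ccccc1Nc1cccc2c1C(=O)N(C1CCC(=O)NC1=O)C2=O`: 7%

In an assay on FRT-Jurkat cells for inhibition of nuclear factor NF-kappa-B complex (Homo sapiens), read by flow cytometry, with a stated time of 24 h, tested at 10 uM (a lower number here means less inhibition, a higher number more inhibition at the concentration tested (going by the name of the read-out)), compound 1 gives 29%, the highest of the three numbers, beyond the scatter from both compound 3 and compound 2. Compound 4 `CC(C)(C)c1ccc(Nc2ccc3c(c2)C(=O)N(C2CCC(=O)NC2=O)C3=O)cc1` is the next compound, not yet measured. It differs from compound 1 in one place: tert-butyl in place of methoxy on an aromatic carbon. The same difference, cut one bond further out, reads 4-methoxyphenyl to 4-(tert-butyl)phenyl, the group sitting para to a large group.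

Going by the values given here, the only measured step, a number 6 percentage points higher from compound 2 to compound 3 (within the scatter), concerns a different exchange on the nitrogen on the aromatic ring and lies within the scatter; it does not bear on a change at the para position of a carbon-only ring. Among the compounds with values here, compounds 1 and 3 differ in more than one place, so their values give no step for this exchange. Within the data shown here, with no step on the aryl substituent measured, no move beyond the scatter is expected in this assay, so the estimated step is a number 1 percentage points higher from compound 1 to compound 4 (within the scatter). Compound 4 is thus expected at about 30%, in the range 10% to 50%.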

Compound 4, a percentage reported as inhibition, at one concentration (the size of the read-out at that concentration, not a potency): 17%
The estimate for compound 4 lay 13 percentage points above the measured number, and the stated range covers the measured number.
By their numbers in this assay, from the lowest: compounds 2, 3 and 4 (each within the scatter of the next, the first and the last beyond it); then compound 1.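

In this assay, going by these compounds alone, tert-butyl in place of methoxy, on an aromatic carbon para to a large group, gives a number 12 percentage points lower from compound 1 to compound 4 (beyond the scatter), the first step read at this position, since the earlier compounds held no exchange on this ring. The position is therefore not indifferent to its substituent, and of these two groups the oxygen-bearing methoxy is the one found with the higher number. The exchange alters both the size of the group and its oxygen, and this single step does not separate the two, while nothing measured on hand accounts for the difference.

Open, on these data alone, is how an amine, a carboxylic acid or a simple hydroxy group at the same place would read against compound 1 and compound 4. Also open, as far as these compounds go, is whether the same exchange would give a step of similar size with the aryl amine at another place on the shared core.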